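Moving From Two Fluorines to One on the Aryl Group

The compounds below may be only part of what the source reports. "The series", "measured", "known", "first", "only" and "open" are said of these compounds alone.

compound 1 `COc1ccccc1-c1ccc2ncn(-c3cc(OC)c(OC)c(OC)c3)c2c1` — 1750 nM
compound 2 `COc1cc(-n2cnc3ccc(-c4cc(F)ccc4F)cc32)cc(OC)c1OC` — 6420 nM

In a functional assay on MCF7 cells (Homo sapiens) for antiproliferative activity, read by MTT assay, with a stated time of 72 h (on this read-out higher numbers stand for weaker inhibition and lower numbers for stronger inhibition), compound 1 gives 1750 nM, while compound 2 gives 6420 nM. Going by the values given here, compound 2 therefore holds the highest number of the two, and the single measured step, a 3.7-fold higher number from compound 1 to compound 2 (0.56 log units; beyond the scatter), shows that trading the 2-methoxyphenyl for the 2,5-difluorophenyl cost a modest amount of potency. Compound 3 `COc1cc(-n2cnc3ccc(-c4ccc(F)cc4)cc32)cc(OC)c1OC` differs from compound 2 only in that place: 4-fluorophenyl in place of 2,5-difluorophenyl on an aromatic carbon. Among the compounds with values here, no measured step exchanges one fluorinated ring for another, so the one step available bears only loosely on this change; it shows that the ring in this position can shift the number by a modest amount, but not which way a single fluorine will go. A step of no more than the modest size seen before is expected, direction uncertain, with a slight lean toward recovery, so compound 3 is estimated at 4000 nM (range 1500 nM to 11000 nM), a step of a 1.6-fold lower number from compound 2 to compound 3 (0.21 log units; within the scatter).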

Compound 3, half-maximal inhibitory concentration: 1770 nM
Estimate against measurement, compound 3: 2.3-fold (0.35 log units) above; low and high end bracket the measured number.
By their numbers in this assay, from the lowest: compounds 1 and 3 (each within the scatter of the next); then compound 2.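

In this assay, this aromatic carbon now has a step between two fluorinated rings: 4-fluorophenyl in place of 2,5-difluorophenyl gives a 3.6-fold lower number from compound 2 to compound 3 (0.56 log units; beyond the scatter), so the number depends on which fluorinated ring is present and not merely on fluorine being there. The 4-fluorophenyl and the 2-methoxyphenyl cannot be told apart here, with a 1.0-fold higher number from compound 1 to compound 3 (0.00 log units; within the scatter), which shows that a swap away from 2-methoxyphenyl need not cost potency as it did in compound 2. Nothing measured here explains these differences.

Going by these compounds, what remains open is whether the pattern extends beyond these three rings. How the number would respond to an unsubstituted phenyl, or to a ring carrying an amine or a carboxylic acid, cannot be told from these compounds.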